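A few compounds are considered here, and "the series" means these few. Any claim that something is new, unique, unknown or untested is made for them only; others in the source may bear on it.

Compound 1, `COc1cc(C(c2ccc(O)c(OC)c2)[C@@H](C)[C@H](C)CO)ccc1O`, in a functional assay on HeLa cells (Homo sapiens) for cytotoxicity, read by WST assay, with a stated time of 48 h (on this read-out higher numbers stand for weaker inhibition and lower numbers for stronger inhibition), gives > 100000 nM, which is a limit of the assay and not a number.
Compound 2, `COC[C@@H](C(C)C)C(c1ccc(O)c(OC)c1)c1ccc(O)c(OC)c1`, in this assay gives 69000 nM.
Compound 3, `CCCCC[C@H](C(C)C)C(c1ccc(O)c(OC)c1)c1ccc(O)c(OC)c1`, in this assay gives 9200 nM.

Compound 1 therefore stands at the limit of > 100000 nM in this assay, at which 1 of the 3 values shown sits, the end of the range where only a limit is reported. Compound 4, `COc1cc(C(c2ccc(O)c(OC)c2)[C@H](C)[C@H](C)CF)ccc1O`, has not yet been measured in this assay. It differs from compound 1 in one place: 2-(fluoromethyl)-1-methylpropyl in place of 2-(hydroxymethyl)-1-methylpropyl on a saturated chain carbon bound to two aromatic carbons.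

Two measured steps start from compound 1 and speak to this change. The first, an at least 1.4-fold lower number from compound 1 to compound 2 (0.16 log units; that floor lies within the scatter), swaps the same side chain for one that also lacks the hydroxymethyl group and is too small to be sure of. The second, an at least 10-fold lower number from compound 1 to compound 3 (1.03 log units; beyond the scatter), swaps it for a 1-isopropylhexyl chain and is large; the related step of a 7.5-fold lower number from compound 2 to compound 3 (0.88 log units; beyond the scatter) shows that most of that gain comes with the longer chain rather than with losing the hydroxymethyl alone. The change in compound 4 keeps the chain the same size as in compound 1 and only exchanges the hydroxymethyl for a fluoromethyl, so it resembles the first step more than the second. A small lowering is therefore expected, an at least 1.6-fold lower number from compound 1 to compound 4 (0.22 log units; that floor lies within the scatter), with a fair chance that only a limit is returned again. The estimate for compound 4 in this assay is 60000 nM, between 20000 nM and 150000 nM.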

Compound 4, half-maximal inhibitory concentration: 75000 nM
Beside the measured number, compound 4's estimate is 1.3-fold (0.10 log units) below it; low and high end bracket the measured number.
By their numbers in this assay, from the lowest: compound 3; then compounds 2 and 4 (each within the scatter of the next). At a limit, above all of these: compound 1.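

Replacing 2-(hydroxymethyl)-1-methylpropyl with 2-(fluoromethyl)-1-methylpropyl on a saturated chain carbon bound to two aromatic carbons gives a measured number in this assay, but the change in potency is small and uncertain: an at least 1.3-fold lower number from compound 1 to compound 4 (0.12 log units; that floor lies within the scatter). Its true size cannot be fixed because compound 1 is known only as a limit of the assay: the limit of > 100000 nM in this assay, at which 1 of the 4 values shown sits. No difference can be claimed between the fluorinated chain and the 1-(methoxymethyl)-2-methylpropyl chain, with a 1.1-fold higher number from compound 2 to compound 4 (0.04 log units; within the scatter), whereas the gap to the 1-isopropylhexyl chain is clear, with an 8.2-fold higher number from compound 3 to compound 4 (0.91 log units; beyond the scatter).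

The compounds shown leave open how an amine or a carboxylic acid at the end of this chain would read in this assay, and whether a longer chain ending in fluoromethyl would reach the level of compound 3. They also cannot separate the effect of chain length from that of the chain's ending, since the 1-isopropylhexyl chain of compound 3 differs from the chain of compound 4 in both.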